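Replacing the 1,3-thiazol-5-yl group of compound 3

The compounds below may be only part of what the source reports. "The series", "measured", "known", "first", "only" and "open" are said of these compounds alone.

Values measured in a functional assay on MCF7 cells (Homo sapiens) for antiproliferative activity, read by CellTiter-Glo, with a stated time of 5 days (on this read-out lower numbers stand for stronger inhibition and higher numbers for weaker inhibition), are as follows
Compound 1 `CC/C(=C(/c1ccc(/C=C/C(=O)O)cc1)c1ccc2[nH]ncc2c1)c1ccccc1` gives 7.2 nM
Compound 2 `CC/C(=C(/c1ccc(/C=C/C(=O)O)cc1)c1ccc2sc(C)nc2c1)c1ccccc1` gives > 500 nM (a limit of the assay, not a number)
Compound 3 `CC/C(=C(/c1ccc(/C=C/C(=O)O)cc1)c1ccc(-c2cncs2)cc1)c1ccccc1` gives 31 nM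

Of the two true numbers, compound 3 holds the higher (31 nM), and compound 1 gives 7.2 nM, a lower number by a gap that lies beyond the scatter. Compound 4 `CC/C(=C(/c1ccc(/C=C/C(=O)O)cc1)c1ccc(-n2ccnc2)cc1)c1ccccc1` differs from compound 3 in one place (1H-imidazol-1-yl in place of 1,3-thiazol-5-yl on an aromatic carbon), with 1H-imidazol-1-yl in place of 1,3-thiazol-5-yl on an aromatic carbon. Within the data shown here, the only measured step (an at least 69-fold higher number from compound 1 to compound 2 (1.84 log units; beyond the scatter)) is large, yet it exchanges other groups and gives no direction here. In this assay no step beyond the scatter is therefore expected, though that large step argues for a wide range. The estimated change is small (a 1.3-fold higher number from compound 3 to compound 4 (0.11 log units; within the scatter)). Compound 4 is expected at 40 nM (estimated range 10 nM to 200 nM).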

Compound 4, half-maximal inhibitory concentration: 380 nM
Estimate against measurement, compound 4: 9.5-fold (0.98 log units) below; measured number above the stated range.
By their numbers in this assay, from the lowest: compound 1; then compound 3; then compound 4. At a limit, above all of these: compound 2.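

In this assay, 1H-imidazol-1-yl in place of 1,3-thiazol-5-yl gives a 12-fold higher number from compound 3 to compound 4 (1.09 log units; beyond the scatter). This place, on an aromatic carbon para to a large group, therefore separates two groups that match in heavy atoms, hydrogen-bond donors, hydrogen-bond acceptors and net charge, so those counts do not settle the outcome here. Compound 2 carries a limit, not a number: the limit of > 500 nM in this assay, at which 1 of the 4 values shown sits.

The compounds shown leave open whether the loss follows the ring's attachment through nitrogen or the departure of sulfur. An imidazole joined through a ring carbon, or a thiophene, would bear on that question.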